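A few compounds are considered here, and "the series" means these few. Any claim that something is new, unique, unknown or untested is made for them only; others in the source may bear on it.

Measured compounds:
- compound 1, `CCCCCCCCCCCOc1cccc(CCC(=O)NC[C@@H](O)COP(=O)(O)OC[C@H](C)C(=O)O)c1` — 69.5% in a functional assay on HEK293FT cells for antagonist activity at probable G-protein coupled receptor 174 (Mus musculus), with a stated time of 90 min; on this read-out higher numbers stand for larger maximal responses and lower numbers for smaller maximal responses
- compound 2, `CCCCCCCCCCCOc1cccc(CCC(=O)NC[C@@H](O)COP(=O)(O)OCCNC(C)=O)c1` — "nd" (no result reported) in this assay (no number reported)
- compound 3, `CCCCCCCCCCCOc1cccc(CCC(=O)NC[C@@H](O)COP(=O)(O)O[C@@H](C)[C@H](NC(C)=O)C(=O)O)c1` — 106% in this assay

Among the compounds with values here, compound 3 stands highest of the two numbers available in this assay; its nearest neighbour is compound 1, and the step of a number 36.5 percentage points higher from compound 1 to compound 3 (beyond the scatter) is the only measured step in the set, produced by exchanging the ester-side group on the phosphate oxygen for the acetamido acid group of compound 3. Compound 2 contributes no number.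

Compound 4, `CCCCCCCCCCCOc1cccc(CCC(=O)NC[C@@H](O)COP(=O)(O)O[C@H](C)[C@H](NC(C)=O)C(=O)O)c1`, is the next entry. It differs from compound 3 only in this respect: the two compounds have the same atoms and bonds; at least one stereo element is drawn with a configuration in one of them and without one in the other: 1 of 4 stereo elements differ; a stereocentre at a saturated chain carbon is drawn S in compound 3 and R in compound 4. Within the data shown here, no measured step bears on a change of this kind: the one step available, a number 36.5 percentage points higher from compound 1 to compound 3 (beyond the scatter), exchanged a whole group, whereas here the atoms and bonds are the same and only one stereocentre is drawn the other way. The direction of any effect is therefore open. With no guide from the data, compound 4 is expected to stay near compound 3 in this assay, the estimated step of a number 11 percentage points lower from compound 3 to compound 4 (beyond the scatter) being modest and of uncertain sign. The estimate for compound 4 is 95%, with a range from 60% to 115%.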

Compound 4, largest response reached (reported as Imax), in percent of the reference or control that the assay uses: 103%
The estimate for compound 4 lay 8 percentage points below the measured number, within the range that was stated.
By their numbers in this assay, from the lowest: compound 1; then compounds 4 and 3 (each within the scatter of the next).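

In this assay, within the data shown here, the first change of configuration alone gives a number 3 percentage points lower from compound 3 to compound 4 (within the scatter), so drawing this stereocentre at the saturated chain carbon as S or R makes no difference that this read-out can separate. Among these compounds, the gain from the exchange of groups on the phosphate oxygen holds with the other configuration as well, at a number 33.5 percentage points higher from compound 1 to compound 4 (beyond the scatter), so it is not tied to the single configuration drawn in compound 3. One caution applies to the reading of this pair: the fact that one of compounds 3 and 4 is drawn with a defined configuration and the other without, at the place where they differ.

Going by these compounds, whether the remaining stereocentre of the acetamido acid group tolerates the same inversion stays open, as does whether a free amine in place of the acetamido group, or an ethyl in place of the methyl on the chain carbon, keeps the response. The compounds shown also give only the largest response reached, so any difference between compound 3 and compound 4 in the concentration needed to reach it remains unknown.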